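The compounds below may be only part of what the source reports. "The series", "measured", "known", "first", "only" and "open" are said of these compounds alone.

Of the compounds shown here, two built on a shared core have been measured so far. In a functional assay on A549 cells (Homo sapiens) for inhibition, read by MTT assay, with a stated time of 48 h (a higher number here means a weaker inhibitor of growth, a lower number a stronger inhibitor of growth), compound 1 `COc1ccc2c(c1)c(C1CC(c3ccc(Cl)cc3)=NN1C(=O)c1ccc(OC)nc1)cn2C` gives 3390 nM, while compound 2 `COc1cccc(C2=NN(C(=O)c3cccnc3)C(c3cn(C)c4ccc(OC)cc34)C2)c1` gives 1020 nM. Compound 2 therefore holds the lower of the two numbers, by a gap beyond the usual scatter. Compound 3 `COc1cccc(C2=NN(C(=O)c3ccc(OC)nc3)C(c3cn(C)c4ccc(OC)cc34)C2)c1` differs from compound 2 in a single place: methoxy in place of hydrogen on an aromatic carbon. A methoxy replaces hydrogen on an aromatic carbon next to the ring nitrogen, turning pyridin-3-yl into 6-methoxypyridin-3-yl. For the measured compounds named here, the only measured compound carrying that 6-methoxypyridin-3-yl group is compound 1 at 3390 nM, which hints at a higher number, but it differs elsewhere too, so the hint is weak. A small expected change toward a higher number, possibly within the scatter, is a 1.5-fold higher number from compound 2 to compound 3 (0.17 log units; within the scatter). The estimated value for compound 3 is 1500 nM, with an expected range from 500 nM to 4000 nM.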

Compound 3, concentration for 50% growth inhibition: 470 nM
Beside the measured number, compound 3's estimate is 3.2-fold (0.50 log units) above it; measured number outside the range, below it.
By their numbers in this assay, from the lowest: compound 3; then compound 2; then compound 1.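

In this assay, placing a methoxy on the aromatic carbon next to the ring nitrogen, which turns pyridin-3-yl into 6-methoxypyridin-3-yl, gives a 2.2-fold lower number from compound 2 to compound 3 (0.34 log units; beyond the scatter), so this place tolerates the added group and the number moves toward stronger growth inhibition. The high number of compound 1 therefore does not follow from the 6-methoxypyridin-3-yl group alone: with that group kept, 3-methoxyphenyl in place of 4-chlorophenyl gives a 7.2-fold lower number from compound 1 to compound 3 (0.86 log units; beyond the scatter). No measurement shown gives a reason for either step.

From the compounds shown here alone, whether an amine or an ethoxy at this same place would give a similar number remains open. So does whether adding the methoxy would have a similar effect in a compound carrying 4-chlorophenyl rather than 3-methoxyphenyl.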